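The source may hold more compounds than are shown below. What is called first, only, known or untested is meant among the compounds shown, and "the series" means these compounds.

Measured so far:
compound 1, `CCCc1cc(N)c2cc(NC(=O)/C=C/c3ccc(F)cc3)ccc2n1`, 130 nM; compound 2, `CCCc1cc(N)c2cc(NC(=O)/C=C/c3ccc(Br)cc3)ccc2n1`, 4 nM; compound 3, `CCCc1cc(N)c2cc(NC(=O)/C=C/c3ccc(O)cc3)ccc2n1`, 1100 nM.

In an assay on isolated protein for displacement of a labelled ligand from melanin-concentrating hormone receptor 1 (Homo sapiens) (on this read-out lower numbers stand for stronger inhibition and higher numbers for weaker inhibition), compound 3 gives the highest number of the three: it sits an 8.5-fold higher number from compound 1 to compound 3 (0.93 log units; beyond the scatter) and a 280-fold higher number from compound 2 to compound 3 (2.44 log units; beyond the scatter). Both of the other compounds carry a halogen on the aromatic carbon where compound 3 carries hydroxy.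

Compound 4, `CCCc1cc(N)c2cc(NC(=O)/C=C/c3ccc(SC)cc3)ccc2n1`, has not yet been measured in this assay . It differs from compound 3 by methylsulfanyl in place of hydroxy on an aromatic carbon.

For the measured compounds named here, the steps that bear on this are a 280-fold higher number from compound 2 to compound 3 (2.44 log units; beyond the scatter) and an 8.5-fold higher number from compound 1 to compound 3 (0.93 log units; beyond the scatter): removing hydroxy in favour of either halogen was accompanied by a markedly lower number, the larger of the two for bromo. Going by the values given here, no measured compound carries methylsulfanyl, so the size of the step to compound 4 rests on the halogen cases alone. On that basis compound 4 is expected to give a lower number than compound 3, estimated as a 110-fold lower number from compound 3 to compound 4 (2.04 log units; beyond the scatter). The estimate for compound 4 in this assay is 10 nM, with a range from 2 nM to 60 nM.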

Compound 4, half-maximal inhibitory concentration: 9 nM
Estimate against measurement, compound 4: 1.1-fold (0.05 log units) above; the range from low to high includes it.
By their numbers in this assay, from the lowest: compound 2; then compound 4; then compound 1; then compound 3.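

In this assay, low numbers at this position are not confined to the halogens: methylsulfanyl in place of hydroxy gives a 120-fold lower number from compound 3 to compound 4 (2.09 log units; beyond the scatter). Methylsulfanyl does not quite match bromo, with a 2.3-fold higher number from compound 2 to compound 4 (0.35 log units; beyond the scatter), but clearly improves on fluoro, with a 14-fold lower number from compound 1 to compound 4 (1.16 log units; beyond the scatter), so the order from the lowest number runs bromo, methylsulfanyl, fluoro, hydroxy. Nothing available explains this order.

The compounds shown leave open whether the high number of compound 3 goes with the hydrogen-bond donor of hydroxy or with the identity of the atom on the ring. Methoxy, which keeps oxygen on the ring and has no hydrogen-bond donor, would bear on that, and chloro or methyl would further test how general the low numbers are at this position.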